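The source may hold more compounds than are shown below. What is called first, only, known or untested is meant among the compounds shown, and "the series" means these compounds.

In an ADME assay on MT4 cells (Homo sapiens) for cytotoxicity, read by MTT assay, with a stated time of 96 h (a higher number here means that more compound is tolerated, a lower number that less compound is tolerated), compound 3 (`NS(=O)(=O)c1ccc(N2N=C(c3ccc(OCc4ccccc4)cc3)CC2c2ccccc2F)cc1`) gives 39000 nM and compound 2 (`Cc1cccc(C2CC(c3ccccc3)=NN2c2ccc(S(N)(=O)=O)cc2)c1`) gives 37000 nM, two values within the scatter of each other. Compound 1 (`NS(=O)(=O)c1ccc(N2N=C(c3ccc(OCc4ccccc4)cc3)CC2c2ccccc2)cc1`) reaches only a limit, > 100000 nM. Compound 4 (`Cc1cccc(C2CC(c3ccc(OCc4ccccc4)cc3)=NN2c2ccc(S(N)(=O)=O)cc2)c1`) has 3-methylphenyl in place of 2-fluorophenyl on a saturated ring carbon. Going by the values given here, the one measured step touching this group is an at least 2.5-fold lower number from compound 1 to compound 3 (0.40 log units; beyond the scatter), for fluoro in place of hydrogen on an aromatic carbon, so losing the fluoro could raise the number. Against that, compound 2, which also carries 3-methylphenyl, gives 37000 nM. The expected change is small, a 1.3-fold higher number from compound 3 to compound 4 (0.11 log units; within the scatter), upward but within the scatter. For compound 4 the estimated value is 50000 nM, with an expected range from 22000 nM to 100000 nM.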

Compound 4, half-maximal cytotoxic concentration: 44000 nM
Beside the measured number, compound 4's estimate is 1.1-fold (0.06 log units) above it, within the range that was stated.
By their numbers in this assay, from the lowest: compounds 2, 3 and 4 (each within the scatter of the next). At a limit, above all of these: compound 1.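

In this assay, swapping the aryl group on the saturated ring carbon gives a 1.1-fold higher number from compound 3 to compound 4 (0.05 log units; within the scatter), so 3-methylphenyl and 2-fluorophenyl are not told apart here, and adding benzyloxy to the other aryl group gives only a 1.2-fold higher number from compound 2 to compound 4 (0.08 log units; within the scatter). Methyl on the phenyl gives an at least 2.2-fold lower number from compound 1 to compound 4 (0.35 log units; beyond the scatter), so the step beyond the scatter seen with fluoro, an at least 2.5-fold lower number from compound 1 to compound 3 (0.40 log units; beyond the scatter), is not confined to fluoro. Both steps start from compound 1, whose value is a limit: the limit of > 100000 nM in this assay, at which 1 of the 4 values shown sits.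

From the compounds shown here alone, whether an amine or a carboxylic acid on this phenyl would move the number remains open. So does the separate role of the substituent's identity and its place on the ring, since 2-fluorophenyl and 3-methylphenyl differ in both.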